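Methyl added to the core: cytotoxicity expectation for compound 3

The source may hold more compounds than are shown below. What is called first, only, known or untested is meant among the compounds shown, and "the series" means these compounds.

Measured compounds and values:
compound 1 `O=C(NCc1ccc(C(F)(F)F)cc1)c1cnc2ccccn2c1=O` — > 200000 nM
compound 2 `O=C(NCc1ccc(F)cc1F)c1cnc2ccccn2c1=O` — > 200000 nM

Both entries in an ADME assay on Huh-7 cells (Homo sapiens) for cytotoxicity, read by MTT assay, with a stated time of 24 h (a higher number here means a weaker inhibitor, a lower number a stronger inhibitor), are limits of the assay rather than numbers. For compound 1 the value > 200000 nM is such a limit. For compound 2 the value > 200000 nM is likewise a limit. Compound 1 therefore stands at the limit of > 200000 nM in this assay, at which 2 of the 2 values shown sit, and nothing in these two entries ranks compound 1 against compound 2; the two values show the same thing and no more.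

Compound 3 `Cc1ccn2c(=O)c(C(=O)NCc3ccc(C(F)(F)F)cc3)cnc2c1` differs from compound 1 by methyl in place of hydrogen on an aromatic carbon of the shared core, with the benzylamide part left unchanged. Within the data shown here, no step between measured compounds exists, so the size of this change has no measured counterpart here. The change adds a single carbon and no donors or acceptors. The step in this assay from compound 1 to compound 3 is expected to be none beyond the scatter, a step that the limit leaves unreadable from compound 1 to compound 3. Compound 3 is estimated at 250000 nM, with a range from 100000 nM to 600000 nM, and is expected most likely to come back again as a limit rather than a number.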

Compound 3, half-maximal inhibitory concentration: > 100000 nM
Compound 3: only a limit was reported; the forecaster's own chance of this, stated with the estimate: 85%; the middle value does not contradict the limit.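

In this assay compound 3 gives > 100000 nM, which is a limit and not a number. Compound 1 also stands at a limit, so no step can be read between compound 1 and compound 3. Still open, going by these compounds, is whether methyl on the shared core changes cytotoxicity at all, since every compound shown sits at a limit.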